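Swapping the aryl group on sulfur: compound 1 to compound 3

This account rests on a few compounds, and the source may have more. Where it says the series, first, only, none or still open, it means among the compounds named here.

In a functional assay on SMMC-7721 cells (Homo sapiens) for inhibition, read by CCK-8 assay, with a stated time of 72 h, tested at 2 uM (on this read-out higher numbers stand for more inhibition of growth at the one concentration tested and lower numbers for less inhibition of growth), compound 1 (`COc1ccc(SCc2ccc(/C=C/C(=O)Nc3ccccc3N)cc2)cc1OC`) gives 14.3%. Within the data shown here, the only comparison available is compound 2 (`Cc1cc(C)cc(SCc2ccc(/C=C/C(=O)Nc3ccccc3N)cc2)c1`), which gives 8.61%. Among the measured compounds shown here, these two numbers lie within the scatter of each other, so compound 1 cannot be ranked against its single measured neighbour.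

The next entry is compound 3 (`Nc1ccccc1NC(=O)/C=C/c1ccc(CSc2ccc(Cl)cc2)cc1`), which keeps the shared core and changes only the aromatic group on the sulfur: 4-chlorophenyl in place of 3,4-dimethoxyphenyl on a sulfur. In words, 4-chlorophenyl stands in place of 3,4-dimethoxyphenyl.

For the measured compounds named here, one measured step bears on this change, as it alters the same place: a number 5.7 percentage points lower from compound 1 to compound 2 (within the scatter). This step stays within the scatter. Going by the values given here, it is thin support, since it is a single step and no measured compound carries 4-chlorophenyl. On this evidence, no step beyond the scatter is expected in this assay, and no direction can be favoured. The estimated step is a number 1.3 percentage points lower from compound 1 to compound 3 (within the scatter), which is not expected to exceed the scatter. Compound 3 is estimated at 13%, with an expected range of 3% to 28%.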

Compound 3, percent growth inhibition at one concentration: 15.2%
Compound 3: middle estimate off by 2.2 percentage points, on the low side, and the stated range covers the measured number.
By their numbers in this assay, from the lowest: compounds 2, 1 and 3 (each within the scatter of the next).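

In this assay, among these compounds, the step to 4-chlorophenyl is the first change on the sulfur that removes both oxygens and brings in a chlorine, and it gives a number 0.9 percentage points higher from compound 1 to compound 3 (within the scatter). Measured against the other aryl group, 4-chlorophenyl in place of 3,5-dimethylphenyl gives a number 6.6 percentage points higher from compound 2 to compound 3 (within the scatter), so the three aryl groups on this sulfur cannot be told apart on this read-out, although the entering group has 0 hydrogen-bond acceptors and the 3,4-dimethoxyphenyl group has 2. The flat picture now holds for groups carrying methoxy, methyl or chloro substituents, and no evidence is at hand to explain it.

Still open, going by these compounds, is whether any group on the sulfur can move the number beyond the scatter, for instance a carboxylic acid or an amine on the aromatic ring, or a saturated chain in place of that ring. All three numbers also come from a single concentration, so whether these compounds would separate at other concentrations remains unsettled.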